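Removing the side chain from compound 3

The source may report more compounds than this note shows. Statements on the series, on what has been measured and on what is new or still open speak of the compounds shown alone.

In a functional assay on A549 cells (Homo sapiens) for cytotoxicity, read by MTT assay, with a stated time of 72 h (a lower number here means a stronger inhibitor, a higher number a weaker inhibitor), the measured compounds read as follows:
Compound 1 `O=C1c2c[n+]([O-])c3ccccc3c2C(=O)c2c1c1ccccc1n2Cc1cn(CC(O)CO)nn1` gives 880 nM
Compound 2 `O=C1c2c[n+]([O-])c3ccccc3c2C(=O)c2c1c1ccccc1n2CCN1CCCC1` gives 410 nM
Compound 3 `CN1CCN(CCCn2c3c(c4ccccc42)C(=O)c2c[n+]([O-])c4ccccc4c2C3=O)CC1` gives 140 nM

Compound 3 has the lowest number of the three, and its gaps to both others lie beyond the scatter. Compound 4 `O=C1c2c[n+]([O-])c3ccccc3c2C(=O)c2[nH]c3ccccc3c21` differs from it by hydrogen in place of 3-(4-methylpiperazin-1-yl)propyl on an aromatic nitrogen and so carries hydrogen in place of 3-(4-methylpiperazin-1-yl)propyl on an aromatic nitrogen. The measured steps bear on this only indirectly. Exchanging one side chain for another gave a 2.1-fold lower number from compound 1 to compound 2 (0.33 log units; beyond the scatter) and a 2.9-fold lower number from compound 2 to compound 3 (0.47 log units; beyond the scatter) and overall a 6.3-fold lower number from compound 1 to compound 3 (0.80 log units; beyond the scatter) and all three count as modest. None of them removes the chain, so no direct measure of the bare nitrogen exists. Compound 3 sits at the low end with 140 nM as its value, so a higher number is expected, though the size is uncertain. The expected change is a 4.3-fold higher number from compound 3 to compound 4 (0.63 log units; beyond the scatter) and it would be a modest one. For compound 4 the estimated value is 600 nM with an expected range from 150 nM to 2500 nM in this assay when it is measured.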

Compound 4, half-maximal inhibitory concentration: 320 nM
Compound 4: middle estimate off by 1.9-fold (0.27 log units), on the high side; the measured number falls inside the stated range.
By their numbers in this assay, from the lowest: compound 3; then compounds 4 and 2 (each within the scatter of the next); then compound 1.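

Replacing the 3-(4-methylpiperazin-1-yl)propyl chain on the aromatic nitrogen with hydrogen gives, in this assay, a 2.3-fold higher number from compound 3 to compound 4 (0.36 log units; beyond the scatter), so the bare nitrogen can now be set against each side chain. Hydrogen there also gives a 2.8-fold lower number from compound 1 to compound 4 (0.44 log units; beyond the scatter), whereas a 1.3-fold lower number from compound 2 to compound 4 (0.11 log units; within the scatter) shows that hydrogen and 2-(pyrrolidin-1-yl)ethyl cannot be told apart, so among these chains only 3-(4-methylpiperazin-1-yl)propyl gives a lower number than hydrogen, and only (1-(2,3-dihydroxypropyl)-1H-1,2,3-triazol-4-yl)methyl a higher one. Nothing available explains these differences.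

The compounds shown leave open whether the lower number of the 3-(4-methylpiperazin-1-yl)propyl chain goes with its ring or with its length, which a 2-(4-methylpiperazin-1-yl)ethyl or 3-(pyrrolidin-1-yl)propyl chain would separate. From the compounds shown here alone, how a plain methyl group on this nitrogen compares with hydrogen also remains open.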